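The source may hold more compounds than are shown below. What is called first, only, known or untested is meant among the compounds shown, and "the series" means these compounds.

Of the compounds shown here, three sharing one core have so far been measured in a functional assay on CHO cells for agonist activity at 5-hydroxytryptamine receptor 1D (Homo sapiens), read by GTPgammaS binding (on this read-out lower numbers stand for an effect already at smaller amounts and higher numbers for an effect only at larger amounts of compound), and they differ only in the amine or carbamate group carried on a saturated chain carbon bound to a saturated ring carbon. Compound 1 `CN(CC1CC1)CC1(O)CCN(CCCc2c[nH]c3ccc(-n4cnnc4)cc23)CC1` gives 1.1 nM. Compound 2 `CC(C)(C)OC(=O)NCC1(O)CCN(CCCc2c[nH]c3ccc(-n4cnnc4)cc23)CC1` gives 9.7 nM. Compound 3 `CN(Cc1ccccc1)CC1(O)CCN(CCCc2c[nH]c3ccc(-n4cnnc4)cc23)CC1` gives 3.8 nM, which leaves compound 3 second highest of the three numbers, with a 2.6-fold lower number from compound 2 to compound 3 (0.41 log units; beyond the scatter) and a 3.5-fold higher number from compound 1 to compound 3 (0.54 log units; beyond the scatter).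

Compound 4 `CC1(C)CCCN(CC2(O)CCN(CCCc3c[nH]c4ccc(-n5cnnc5)cc34)CC2)C1` has not been measured. Its change from compound 3 is 3,3-dimethylpiperidin-1-yl in place of benzyl(methyl)amino on a saturated chain carbon bound to a saturated ring carbon. Going by the values given here, two measured steps bear on this change. The step of a 3.5-fold higher number from compound 1 to compound 3 (0.54 log units; beyond the scatter) shows that replacing a small aliphatic group with a phenyl on the amine raised the number, and the step of a 2.6-fold lower number from compound 2 to compound 3 (0.41 log units; beyond the scatter) shows that a tertiary amine in place of the carbamate lowered it. Compound 4 keeps a tertiary amine but returns to purely aliphatic substituents, closed into a ring, which resembles compound 1 more than compound 3 in that respect. The expected outcome is therefore a modest lowering in this assay, roughly a 1.7-fold lower number from compound 3 to compound 4 (0.24 log units; within the scatter). For compound 4 the estimated value is 2.2 nM, with a likely range from 0.7 nM to 7 nM.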

Compound 4, concentration for half-maximal effect: 0.9 nM
Compound 4: the middle estimate sits 2.4-fold (0.39 log units) above what was measured, and the stated range covers the measured number.
By their numbers in this assay, from the lowest: compounds 4 and 1 (each within the scatter of the next); then compound 3; then compound 2.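

Replacing benzyl(methyl)amino with 3,3-dimethylpiperidin-1-yl on the saturated chain carbon gives a 4.2-fold lower number from compound 3 to compound 4 (0.63 log units; beyond the scatter) in this assay, so at this position the amine needs no aromatic ring, and its nitrogen substituents can be closed into a ring. Against the open-chain amine, the result is a 1.2-fold lower number from compound 1 to compound 4 (0.09 log units; within the scatter), so the ring and (cyclopropylmethyl)(methyl)amino cannot be told apart here, while the step from the carbamate, an 11-fold lower number from compound 2 to compound 4 (1.03 log units; beyond the scatter), is the largest listed so far and the only one rated large. Among these four compounds, the two amines without an aromatic ring, compound 1 and compound 4, therefore hold the lowest numbers, but no measurement shown explains these differences.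

As far as these compounds go, what the two methyl groups of the ring contribute remains open, and plain piperidin-1-yl at the same place would test this directly. It is also unknown whether a morpholin-4-yl ring, with an added oxygen, or a smaller pyrrolidin-1-yl ring would keep the number as low as in compound 4.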